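A few compounds are considered here, and "the series" means these few. Any claim that something is new, unique, unknown or untested is made for them only; others in the source may bear on it.

Measured so far in an assay on isolated protein for displacement of a labelled ligand from melanin-concentrating hormone receptor 1 (Homo sapiens); a higher number here means a weaker inhibitor, a lower number a stronger inhibitor:
compound 1 `CC1CCCN1c1ccc2cc(NC(=O)CCc3ccc(C(F)(F)F)cc3)ccc2n1` gives 5 nM
compound 2 `O=C(CCc1ccc(C(F)(F)F)cc1)Nc1ccc2nc(N3CC4CC3CO4)ccc2c1` gives 13 nM
compound 3 `O=C(CCc1ccc(C(F)(F)F)cc1)Nc1ccc2nc(N3CCC4(CCNC4)C3)ccc2c1` gives 0.5 nM

Compound 3 stands at the lowest number of the three, that is, it is the strongest inhibitor measured here. It reached that position through the steps from compound 1 to compound 3 (a 10-fold lower number from compound 1 to compound 3 (1.00 log units; beyond the scatter)) and from compound 2 to compound 3 (a 26-fold lower number from compound 2 to compound 3 (1.41 log units; beyond the scatter)); in both, the group that entered was the one with two five-membered non-aromatic rings, a second nitrogen and a hydrogen-bond donor.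

Compound 4 `O=C(CCc1ccc(C(F)(F)F)cc1)Nc1ccc2nc(N3CC4CCC3CC4)ccc2c1` differs from compound 3 in one place: a group of 8 heavy atoms (7 carbon, 1 nitrogen; 2 six-membered non-aromatic rings with 1 hetero atom each) in place of a group of 9 heavy atoms (7 carbon, 2 nitrogen; 2 five-membered non-aromatic rings with 1 hetero atom each), on an aromatic carbon. The group that now leaves is exactly the one whose arrival lowered the number in both earlier steps, and what enters has no hydrogen-bond donor and one fewer nitrogen, as in compound 1. The number for compound 4 is therefore expected to rise, with a step of about a 16-fold higher number from compound 3 to compound 4 (1.20 log units; beyond the scatter), landing near the value of compound 1. The estimate for compound 4 in this assay is 8 nM, with a range from 2 nM to 30 nM.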

Compound 4, half-maximal inhibitory concentration: 3 nM
For compound 4 the middle estimate is 2.7-fold (0.43 log units) above the measured one, within the range that was stated.
By their numbers in this assay, from the lowest: compound 3; then compounds 4 and 1 (each within the scatter of the next); then compound 2.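

In this assay the change at this position gives a 6.0-fold higher number from compound 3 to compound 4 (0.78 log units; beyond the scatter) and shows that a strong inhibitor does not need the second nitrogen or the hydrogen-bond donor of compound 3, even though the number does rise when they leave. Groups without that second nitrogen are not all alike: a 4.3-fold lower number from compound 2 to compound 4 (0.64 log units; beyond the scatter) separates two of them as the oxygen-bearing group gives way to the group with 2 six-membered non-aromatic rings, while a 1.7-fold lower number from compound 1 to compound 4 (0.22 log units; within the scatter) stays within the scatter. Nothing measured here explains these differences.

The compounds shown leave open whether the gain in compound 3 comes from the second nitrogen itself or from the hydrogen on it. A methyl group on that nitrogen, or an oxygen in its place, would help to separate the two.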